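A few compounds are considered here, and "the series" means these few. Any claim that something is new, unique, unknown or untested is made for them only; others in the source may bear on it.

Compound 3 `NC(=O)c1ccc(-c2cnc(C(=O)CCCCCCc3ccccc3)o2)cc1` gives 10 nM in an assay (Rattus norvegicus) for inhibition of Fatty-acid amide hydrolase 1 (Homo sapiens); a higher number here means a weaker inhibitor, a lower number a stronger inhibitor. Among the three measured compounds it stands second highest: compound 1 `NC(=O)c1cccc(-c2cnc(C(=O)CCCCCCc3ccccc3)o2)c1` gives 6 nM, with the carbamoyl moved, and compound 2 `Nc1ccc(-c2cnc(C(=O)CCCCCCc3ccccc3)o2)cc1` gives 90 nM, with an amino in its place. Moving the carbamoyl changes little, as a 1.7-fold higher number from compound 1 to compound 3 (0.22 log units; within the scatter) shows, whereas swapping amino for carbamoyl is a larger matter, as a 9.0-fold lower number from compound 2 to compound 3 (0.95 log units; beyond the scatter) and a 15-fold higher number from compound 1 to compound 2 (1.18 log units; beyond the scatter) show. The change to compound 4 `Cc1cccnc1-c1cnc(C(=O)CCCCCCc2ccccc2)o1` is 3-methylpyridin-2-yl in place of 4-carbamoylphenyl on an aromatic carbon. For the measured compounds named here, no measured step swaps the whole aryl group for a pyridyl, so the only guidance is that the aryl group on this carbon of the shared core can shift this assay by a modest amount. Because a 9.0-fold lower number from compound 2 to compound 3 (0.95 log units; beyond the scatter) shows that a ring without the carbamoyl gives a higher number, compound 4 is expected to give a somewhat higher number, a step of about a 2.5-fold higher number from compound 3 to compound 4 (0.40 log units; beyond the scatter) in this assay, though with little confidence. Compound 4 is therefore estimated at 25 nM, within a range from 6 nM to 100 nM.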

Compound 4, inhibition constant: 15 nM
For compound 4 the middle estimate is 1.7-fold (0.22 log units) above the measured one; the range from low to high includes it.
By their numbers in this assay, from the lowest: compounds 1, 3 and 4 (each within the scatter of the next, the first and the last beyond it); then compound 2.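

In this assay, the carbamoyl group proves not to be required on this carbon of the shared core: with 3-methylpyridin-2-yl in place of 4-carbamoylphenyl there is a 1.5-fold higher number from compound 3 to compound 4 (0.18 log units; within the scatter), even though the entering group has no hydrogen-bond donor. Losing the carbamoyl therefore does not by itself give a high number, as a 6.0-fold lower number from compound 2 to compound 4 (0.78 log units; beyond the scatter) shows, although neither of these two rings carries that group. Against the 3-carbamoylphenyl ring a modest gap does remain, with a 2.5-fold higher number from compound 1 to compound 4 (0.40 log units; beyond the scatter).

Going by these compounds, it stays open whether the ring nitrogen or the methyl matters here, and what an unsubstituted pyridin-2-yl, a plain phenyl or a phenyl bearing a carboxylic acid would give. Nothing shown offers a measured reason for any of these steps.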